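The compounds below may be only part of what the source reports. "The series", "measured", "known", "first", "only" and "open" are said of these compounds alone.

Of the compounds shown here, three built on one shared core have been measured so far. Compound 1 `CCSc1nc2c(cc(-c3ccc(C)cc3)n2-c2ccccc2)c(=N)s1` gives 0% in a functional assay on the whole organism for inhibition, with Rattus norvegicus as the target, read by ELISA, with stated times of 30 min and 6 h, at a dose of 30 mg/kg by the oral route; on this read-out higher numbers stand for more inhibition at the one dose given (going by the name of the read-out) and lower numbers for less inhibition. Compound 2 `CCSc1nc2c(cc(-c3ccc(Br)cc3)n2-c2ccccc2)c(=N)s1` differs from compound 1 by bromo in place of methyl on an aromatic carbon, and in this assay compound 2 gives 1%. The step here is a number 1 percentage points higher from compound 1 to compound 2 (within the scatter). Compound 3 `CCC(C)Sc1nc2c(cc(-c3ccc(C)cc3)n2-c2ccccc2)c(=N)s1` differs from compound 1 in its core by ethyl in place of hydrogen on a saturated chain carbon bound to a saturated chain carbon and a sulfur, and in this assay compound 3 gives 2%. That step is a number 2 percentage points higher from compound 1 to compound 3 (within the scatter).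

Compound 4 `CCC(C)Sc1nc2c(cc(-c3ccc(Br)cc3)n2-c2ccccc2)c(=N)s1` has not yet been measured. It differs from compound 3 by bromo in place of methyl on an aromatic carbon. This is the same change that was already made between two measured compounds, at the same place on the ring, where the step was a number 1 percentage points higher from compound 1 to compound 2 (within the scatter). All three measured numbers sit close to the bottom of the scale, so nothing in them points to a large step. The step from compound 3 to compound 4 is expected to be no change at the digits printed from compound 3 to compound 4 (within the scatter). Compound 4 is estimated at 2%, with a likely range from 0% to 12%.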

Compound 4, a percentage reported as inhibition, in the whole organism at one dose (the size of the read-out at that dose, not a potency): 70%
Compound 4: the middle estimate sits 68 percentage points below what was measured, outside the stated range (above it).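

In this assay, the change from 4-methylphenyl to 4-bromophenyl gives a number 68 percentage points higher from compound 3 to compound 4 (beyond the scatter), yet the same change on the core of compound 1 gives a very different result: the same change on two cores in this assay, a number 1 percentage points higher (within the scatter) from compound 1 to compound 2 and a number 68 percentage points higher (beyond the scatter) from compound 3 to compound 4, 67 percentage points apart, beyond the scatter of two such steps. The second change, ethyl in place of hydrogen on the chain carbon bound to sulfur, behaves the same way, giving a number 69 percentage points higher from compound 2 to compound 4 (beyond the scatter) when bromo is already present, and it too fails to carry over: the same change on two cores in this assay, a number 2 percentage points higher (within the scatter) from compound 1 to compound 3 and a number 69 percentage points higher (beyond the scatter) from compound 2 to compound 4, 67 percentage points apart, beyond the scatter of two such steps. In these four compounds, then, neither change has a fixed size that can be carried from one core to another, and the high number appears only in compound 4, which holds both changes, but the data do not show why the two work together or whether this would hold on any other core.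

The compounds shown leave open whether chloro or iodo could stand in for bromo alongside the ethyl. They also leave open whether a longer chain in place of the ethyl would keep, raise or lose the number seen for compound 4.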